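Shifting a Nitro Group Around a Phenyl Ring

The compounds below may be only part of what the source reports. "The series", "measured", "known", "first", "only" and "open" are said of these compounds alone.

Two measured compounds share one core and differ only in the aryl group at one end. Compound 1 `Cc1ccc(-c2nnc(CSc3nnc(/N=C/c4ccccc4O)s3)o2)cc1` carries a 4-methylphenyl group, and in a functional assay on A549 cells (Homo sapiens) for inhibition, read by CCK-8 assay (a lower number here means a stronger inhibitor, a higher number a weaker inhibitor), compound 1 gives 22000 nM. Compound 2 `O=[N+]([O-])c1cccc(-c2nnc(CSc3nnc(/N=C/c4ccccc4O)s3)o2)c1` carries a 3-nitrophenyl group instead, and in this assay compound 2 gives 36900 nM. Among the compounds with values here, of the two numbers measured so far this is the higher one, yet the step of a 1.7-fold higher number from compound 1 to compound 2 (0.22 log units; within the scatter) lies within the scatter, so the two compounds cannot be told apart by this measurement.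

Compound 3 `O=[N+]([O-])c1ccc(-c2nnc(CSc3nnc(/N=C/c4ccccc4O)s3)o2)cc1` keeps the same atoms and simply rearranges one group: 4-nitrophenyl in place of 3-nitrophenyl on an aromatic carbon. Within the data shown here, no measured step of this kind exists here; the only step known is the swap of 4-methylphenyl for 3-nitrophenyl, which stayed within the scatter. There is therefore no basis for expecting a change beyond the scatter in this assay, and the expected step is a 1.1-fold lower number from compound 2 to compound 3 (0.02 log units; within the scatter). For compound 3 in this assay the estimate is 35000 nM, with a likely range from 14000 nM to 90000 nM.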

Compound 3, half-maximal inhibitory concentration: 4130 nM
Beside the measured number, compound 3's estimate is 8.5-fold (0.93 log units) above it, outside the stated range (below it).
By their numbers in this assay, from the lowest: compound 3; then compounds 1 and 2 (each within the scatter of the next).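

Until now this end of the molecule had shown no change beyond the scatter in this assay, but the new result shows that the aryl group on this aromatic carbon can matter, and that moving the nitro group around the phenyl ring is enough on its own. With the same atoms joined differently, 4-nitrophenyl in place of 3-nitrophenyl gives an 8.9-fold lower number from compound 2 to compound 3 (0.95 log units; beyond the scatter) in this assay, while nitro in place of methyl gives a 5.3-fold lower number from compound 1 to compound 3 (0.73 log units; beyond the scatter) from the 4-substituted comparison, so having a nitro group on the ring does not by itself set the number: 3-nitrophenyl could not be told apart from 4-methylphenyl, yet 4-nitrophenyl stands apart from both. Nothing available here accounts for this difference.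

The compounds shown leave open how 2-nitrophenyl would compare, which would complete the set of places for the nitro group on this ring. They also leave open whether the result belongs to the nitro group itself or would hold for another group in its place in 4-nitrophenyl, such as a nitrile, an amine or a carboxylic acid.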